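Chain-end variation in an aryl ether series

The source may report more compounds than this note shows. Statements on the series, on what has been measured and on what is new or still open speak of the compounds shown alone.

The series shares an acetyl-phenol core carrying an ether chain with a variable terminus. Compound 1 `CCc1cc(C(C)=O)c(O)cc1OCCCC(C)(C)C#N` ends in a nitrile; in an assay on isolated protein for binding affinity to leukotriene B4 receptor 1 (Homo sapiens), tested at 1 uM (on this read-out lower numbers stand for less inhibition and higher numbers for more inhibition at the one concentration tested (going by the name of the read-out)), compound 1 gives 46%. Compound 2 `CCc1cc(C(C)=O)c(O)cc1OCCCC(C)(C)C(N)=O` carries a primary amide at the same carbon, and compound 2 gives 51%; the step of a number 5 percentage points higher from compound 1 to compound 2 (within the scatter) is within the scatter. Compound 3 `CCc1cc(C(C)=O)c(O)cc1OCCCCCC(C)(C)c1nnn(C)n1`, with a longer chain and a methyltetrazolyl terminus, gives 66%, the highest of the three numbers, above compound 2 and compound 1 by margins beyond the scatter.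

Compound 4 `CCc1cc(C(C)=O)c(O)cc1OCCCCCCC(=O)N(C)C` differs from compound 3 in one place: (dimethylcarbamoyl)methyl in place of 1-methyl-1-(2-methyl-2H-tetrazol-5-yl)ethyl on a saturated chain carbon, five bonds along the chain from an oxygen on an aromatic ring. Going by the values given here, no measured step covers this change directly. Among the compounds with values here, the one step in hand, from compound 1 to compound 2, exchanged two small polar termini on a crowded chain carbon and stayed within the scatter; the present change removes the aromatic ring and the two methyls and moves toward the amide type seen in compound 2. A fall toward the level of compound 2 is therefore expected, rather than no change, giving an estimated step of a number 16 percentage points lower from compound 3 to compound 4 (beyond the scatter). Compound 4 is estimated at 50%, with a range from 35% to 65%.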

Compound 4, a percentage reported as inhibition, at one concentration (the size of the read-out at that concentration, not a potency): 61%
Beside the measured number, compound 4's estimate is 11 percentage points below it; low and high end bracket the measured number.
By their numbers in this assay, from the lowest: compounds 1, 2, 4 and 3 (each within the scatter of the next, the first and the last beyond it).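

In this assay the exchange of 1-methyl-1-(2-methyl-2H-tetrazol-5-yl)ethyl for (dimethylcarbamoyl)methyl on a saturated chain carbon, five bonds along the chain from an oxygen on an aromatic ring, gives a number 5 percentage points lower from compound 3 to compound 4 (within the scatter) and thus shows that, in this pair, the read-out holds without the five-membered aromatic ring or the two methyls of the leaving group. Against the shorter ends, 3-(dimethylcarbamoyl)propyl in place of 1-carbamoyl-1-methylethyl gives a number 10 percentage points higher from compound 2 to compound 4 (within the scatter) in this assay, while the same group in place of 1-cyano-1-methylethyl, on a saturated chain carbon three bonds along the chain from an oxygen on an aromatic ring, gives a number 15 percentage points higher from compound 1 to compound 4 (beyond the scatter) and is the only one of the three new steps beyond the scatter. No supporting data bear on the origin of these numbers.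

Both steps from the shorter ends change the chain and its terminal group together, which leaves the contribution of each unresolved. Also open, on these data alone, is how a carboxylic acid, an amine or a longer chain carrying the dimethylcarbamoyl end would read in this assay at this position.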